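The source may hold more compounds than are shown below. What is called first, only, known or untested is meant among the compounds shown, and "the series" means these compounds.

Of the compounds shown here, three have numbers so far in a functional assay on NCI-H460 cells (Homo sapiens) for cytotoxicity, read by MTT assay, with a stated time of 3 days (on this read-out lower numbers stand for stronger inhibition and higher numbers for weaker inhibition), on the shared core. Compound 1 (`N#Cc1c(O)nc(SCc2nc3ccccc3[nH]2)nc1-c1ccccc1`) stands at 2.5 nM and compound 2 (`N#Cc1c(Cl)nc(SCc2nc3ccccc3[nH]2)nc1-c1ccccc1`) at 3.28 nM while compound 3 (`N#Cc1c(NN)nc(SCc2nc3ccccc3[nH]2)nc1-c1ccccc1`) gives 2.6 nM on the same read-out. Compound 3 therefore sits level with both others, inside the scatter.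

Compound 4 (`N#Cc1c(Nc2ccccc2)nc(SCc2nc3ccccc3[nH]2)nc1-c1ccccc1`) departs from compound 3 as phenyl in place of amino on a nitrogen on an aromatic ring shows: phenyl in place of amino on a nitrogen on an aromatic ring.

The measured exchanges on an aromatic carbon bear on this: the series shows a 1.0-fold higher number from compound 1 to compound 3 (0.02 log units; within the scatter) and a 1.3-fold lower number from compound 2 to compound 3 (0.10 log units; within the scatter) as well as a 1.3-fold higher number from compound 1 to compound 2 (0.12 log units; within the scatter) and all three lie within the scatter. None of those exchanges brought in a ring, so the data leave phenyl untested and the range stays wide. No step beyond the scatter is expected in this assay in either direction. The step expected is a 1.2-fold higher number from compound 3 to compound 4 (0.06 log units; within the scatter) by this estimate. For compound 4 the estimate is 3 nM with an expected range from 1.2 nM to 9 nM on this reasoning.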

Compound 4, half-maximal inhibitory concentration: 4.54 nM
For compound 4 the middle estimate is 1.5-fold (0.18 log units) below the measured one; the measured number falls inside the stated range.
By their numbers in this assay, from the lowest: compounds 1, 3, 2 and 4 (each within the scatter of the next).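

Phenyl in place of amino on a nitrogen on an aromatic ring brings the first ring into this place, and in this assay the result stays level, with a 1.7-fold higher number from compound 3 to compound 4 (0.24 log units; within the scatter). Anilino also stays level against the two smaller groups on the aromatic carbon, with a 1.4-fold higher number from compound 2 to compound 4 (0.14 log units; within the scatter) and a 1.8-fold higher number from compound 1 to compound 4 (0.26 log units; within the scatter), so the added six-membered aromatic ring of carbon only opens no step beyond the scatter among these four compounds. No measurement available here explains this flat response.

Still open, from the compounds shown here alone, is whether any group on this aromatic carbon separates from these four, for instance a morpholine, a carboxylic acid or a longer alkyl chain. Also open, going by these compounds, is whether a methoxy or a chloro on the anilino ring would move the number beyond the scatter.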